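Adding a Methoxy Group Next to the Ring Nitrogen

This account rests on a few compounds, and the source may have more. Where it says the series, first, only, none or still open, it means among the compounds named here.

Of the compounds shown here, three have so far been tested in a functional assay on HeLa cells (Homo sapiens) for inhibition, read by MTT assay, with a stated time of 48 h; a higher number here means a weaker inhibitor of growth, a lower number a stronger inhibitor of growth. Compound 1 `COc1ccc(C2=NN(C(=O)c3cccnc3)C(c3cn(C)c4ccc(Br)cc34)C2)cc1OC` gives 2090 nM. Compound 2 `COc1cc(C2=NN(C(=O)c3cccnc3)C(c3cn(C)c4ccc(Br)cc34)C2)cc(OC)c1OC` differs from compound 1 by methoxy in place of hydrogen on an aromatic carbon. For compound 2 the assay returned only a limit, > 10000 nM (the limit of > 10000 nM in this assay, at which 1 of the 3 values shown sits). The step is an at least 4.7-fold higher number from compound 1 to compound 2 (0.67 log units; beyond the scatter). Compound 3 `COc1ccc2c(c1)c(C1CC(c3ccccc3)=NN1C(=O)c1cccnc1)cn2C` gives 3590 nM in this assay; the difference between the cores of compound 1 and compound 3 is not broken down here, and their two values lie within the usual scatter.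

Compound 4 `COc1ccc2c(c1)c(C1CC(c3ccccc3)=NN1C(=O)c1ccc(OC)nc1)cn2C` is not yet measured; it differs from compound 3 by methoxy in place of hydrogen on an aromatic carbon. This is the same kind of change as from compound 1 to compound 2, but not the same: there the methoxy entered on a ring of carbon only, ortho to a methoxy group and meta to a large group, whereas here it enters on a ring with one nitrogen, next to the ring nitrogen and para to a large group. Among the compounds with values here, because an at least 4.7-fold higher number from compound 1 to compound 2 (0.67 log units; beyond the scatter) is the only measured example of this kind, a higher number is also expected for compound 4, with less certainty given the different surroundings: a 1.9-fold higher number from compound 3 to compound 4 (0.29 log units; within the scatter). The estimate for compound 4 is 7000 nM, between 2500 nM and 20000 nM.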

Compound 4, concentration for 50% growth inhibition: 1100 nM
Compound 4: middle estimate off by 6.4-fold (0.80 log units), on the high side; the measured number lies below the stated range.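

In this assay, turning pyridin-3-yl into 6-methoxypyridin-3-yl gives a 3.3-fold lower number from compound 3 to compound 4 (0.51 log units; beyond the scatter), so here the methoxy goes with a stronger inhibitor of growth. Set beside the earlier step, the same kind of change does not carry over from one core to the other, and its direction reverses: the same change on two cores in this assay, an at least 4.7-fold higher number (0.67 log units; beyond the scatter) from compound 1 to compound 2 and a 3.3-fold lower number (0.51 log units; beyond the scatter) from compound 3 to compound 4, at least 15-fold (1.19 log units) apart, beyond the scatter of two such steps The pairs do not show what decides that direction, since the two steps differ in the ring that takes the methoxy, in its place on that ring and in the rest of the compound, and no single one of these differences can be singled out.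

On these data alone, it remains open whether a methoxy next to the ring nitrogen would also lower the number on the core of compound 1, which would separate the effect of the ring from that of the rest of the compound. Also open, as far as these compounds go, is whether an amine or an ethoxy group in that place would act as the methoxy does in compound 4.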